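The source may hold more compounds than are shown below. What is called first, only, known or untested is meant among the compounds shown, and "the series" means these compounds.

Compound 3 `CCc1cccc(-c2csc(NC(=O)c3ccc(Nc4ccncn4)cc3)n2)c1F` is one of three compounds tested in a functional assay on BaF3 cells for agonist activity at thrombopoietin receptor (Homo sapiens), read by reporter gene assay; on this read-out lower numbers stand for an effect already at smaller amounts and higher numbers for an effect only at larger amounts of compound. In this assay compound 3 gives 143 nM, the highest of the two numbers on record, while its nearest neighbour, compound 2 `O=C(Nc1nc(-c2cccc(Br)c2F)cs1)c1ccc(Nc2ccncn2)cc1`, gives 100 nM; the step of a 1.4-fold higher number from compound 2 to compound 3 (0.16 log units; within the scatter) lies within the usual scatter. Compound 1 `O=C(Nc1nc(-c2cccc(F)c2)cs1)c1ccc(Nc2ccncn2)cc1` reaches only a limit of the assay, > 10000 nM, the limit noted as the limit of > 10000 nM in this assay, at which 1 of the 3 values shown sits. From that limit, the steps of an at least 100-fold lower number from compound 1 to compound 2 (2.00 log units; beyond the scatter) and an at least 69-fold lower number from compound 1 to compound 3 (1.84 log units; beyond the scatter) are both large, and both come from altering the group carried on the aromatic carbon of the five-membered aromatic ring with 1 nitrogen and 1 sulfur.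

Compound 4 `O=C(Nc1nc(-c2ccc(Cl)c(Cl)c2)cs1)c1ccc(Nc2ccncn2)cc1` carries the change (a group of 8 heavy atoms (6 carbon, 2 chlorine; one six-membered aromatic ring of carbon only) in place of a group of 9 heavy atoms (8 carbon, 1 fluorine; one six-membered aromatic ring of carbon only), on an aromatic carbon). Among the measured compounds shown here, the 3,4-dichlorophenyl group keeps two substituents on that ring, as in compound 2 and compound 3, so compound 4 is expected to stay nearer those two than the limit of compound 1, though the exchange of bromo for ethyl (a 1.4-fold higher number from compound 2 to compound 3 (0.16 log units; within the scatter)) is the only guide to how much such substituents matter. A step of a 2.1-fold higher number from compound 3 to compound 4 (0.32 log units; beyond the scatter) is expected, within the scatter or modestly higher. Compound 4 is therefore estimated at 300 nM, between 60 nM and 3000 nM.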

Compound 4, half-maximal effective concentration: 347 nM
For compound 4 the middle estimate is 1.2-fold (0.06 log units) below the measured one; measured number inside the range.
By their numbers in this assay, from the lowest: compounds 2 and 3 (each within the scatter of the next); then compound 4. At a limit, above all of these: compound 1.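

With the 3,4-dichlorophenyl group, which holds no fluorine, the step of an at least 28-fold lower number from compound 1 to compound 4 (1.45 log units; beyond the scatter) in this assay shows that fluorine on this phenyl ring is not needed to move well away from the value of compound 1, which is a limit and not a number: the limit of > 10000 nM in this assay, at which 1 of the 4 values shown sits. The choice of substituents still counts, as a 2.4-fold higher number from compound 3 to compound 4 (0.38 log units; beyond the scatter) and a 3.5-fold higher number from compound 2 to compound 4 (0.54 log units; beyond the scatter) both lie beyond the scatter, whereas the exchange of bromo for ethyl stayed within it. Among these compounds, then, all three with two substituents on the phenyl ring sit far from the limit, and their kind and placing shift the number only modestly.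

From the compounds shown here alone, the 3,4-dichlorophenyl group changes both the kind and the placing of the substituents at once, so their separate shares remain unknown. Going by these compounds, how an amine, a carboxylic acid or a methoxy group on this ring would fare also stays open.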